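The compounds below may be only part of what the source reports. "The series", "measured", "known", "first", "only" and "open" are said of these compounds alone.

Measured compounds:
compound 1 `Cc1ccccc1-n1cc(-c2ccc(NS(=O)(=O)c3c[nH]c(=O)[nH]c3=O)cc2)nn1` — 7310 nM
compound 2 `O=c1[nH]cc(S(=O)(=O)Nc2ccc(-c3cn(-c4ccccc4F)nn3)cc2)c(=O)[nH]1` — 8030 nM

Going by the values given here, in a functional assay on OVCAR-3 cells (Homo sapiens) for antiproliferative activity, read by MTT assay, with a stated time of 24 h (on this read-out higher numbers stand for weaker inhibition and lower numbers for stronger inhibition), compound 2 gives the higher of the two numbers, and its only neighbour is compound 1 with the step of a 1.1-fold higher number from compound 1 to compound 2 (0.04 log units; within the scatter) lying within the scatter. Compound 3 `O=c1[nH]cc(S(=O)(=O)Nc2ccc(-c3cn(-c4cccc(F)c4)nn3)cc2)c(=O)[nH]1` is the next analogue: 3-fluorophenyl in place of 2-fluorophenyl on an aromatic nitrogen. Among the compounds with values here, no measured step moves the fluorine around the ring; the sole step, from compound 1 to compound 2, swaps one group for another at an unchanged position and is itself within the scatter. A step of a 1.0-fold lower number from compound 2 to compound 3 (0.00 log units; within the scatter) is therefore expected, with no change beyond the scatter. Compound 3 is estimated at 8000 nM in this assay, range 3500 nM to 18000 nM.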

Compound 3, half-maximal inhibitory concentration: > 20000 nM
Compound 3: only a limit was reported (the forecaster's own chance of this, stated with the estimate: 5%); middle value at least 2.5-fold (0.39 log units) from the limit.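

Shifting the fluorine on the phenyl at this aromatic nitrogen moves the read-out where the earlier swap of methyl for fluoro did not: in this assay the change gives an at least 2.4-fold higher number from compound 2 to compound 3 (0.39 log units; beyond the scatter). The swap from 2-methylphenyl to 3-fluorophenyl gives an at least 2.7-fold higher number from compound 1 to compound 3 (0.43 log units; beyond the scatter), so among these compounds only the 3-fluorophenyl stands apart. Compound 3 is reported only as a limit: the limit of > 20000 nM in this assay, at which 1 of the 3 values shown sits. From the compounds shown here alone, how far compound 3 lies past that limit stays open. Also open, going by these compounds, is whether another group in the same place on the phenyl, such as chloro or an amine, would behave like the fluorine.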